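A few compounds are considered here, and "the series" means these few. Any claim that something is new, unique, unknown or untested is made for them only; others in the source may bear on it.

Measured so far in a functional assay on KB cells (Homo sapiens) for inhibition, read by MTT assay, with a stated time of 24 h, tested at 0.1 ug/mL; a higher number here means more inhibition of growth at the concentration tested, a lower number less inhibition of growth:

compound 1 `O=C(CCCCC(S)CCS)Nc1ccccc1`: 9.49%
compound 2 `O=C(CCCCC(S)CCS)Nc1ccc(Cl)cc1`: 9.11%
compound 3 `O=C(CCCCC(CCSC(=O)c1ccccc1)SC(=O)c1ccccc1)Nc1ccccc1`: 1.52%

Compound 1 and compound 2 differ by chloro in place of hydrogen on an aromatic carbon. This step gave a number 0.4 percentage points lower from compound 1 to compound 2 (within the scatter). Compound 3 has a different core from compound 1; the difference between the two cores is not broken down here. Compound 4 `O=C(CCCCC(CCSC(=O)c1ccccc1)SC(=O)c1ccccc1)Nc1ccccc1Cl` is not yet measured; it differs from compound 3 by chloro in place of hydrogen on an aromatic carbon. The two places are not identical: in compound 2 the chloro stands para to a large group, in compound 4 ortho to a large group, so this counts as the same kind of change, not the same change. In this assay the step from compound 3 to compound 4 is expected to be small, a number 1 percentage points higher from compound 3 to compound 4 (within the scatter), because the earlier one was a number 0.4 percentage points lower from compound 1 to compound 2 (within the scatter) and compound 3 gives 1.52%. Compound 4 is thus estimated at 2.5%, expected between 0% and 9%.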

Compound 4, percent growth inhibition at one concentration: 3.62%
For compound 4 the middle estimate is 1.1 percentage points below the measured one, within the range that was stated.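

In this assay, chloro in place of hydrogen on an aromatic carbon gave a number 2.1 percentage points higher from compound 3 to compound 4 (within the scatter), and the two steps for this change do not differ across the two cores: the same change on two cores in this assay, a number 0.4 percentage points lower (within the scatter) from compound 1 to compound 2 and a number 2.1 percentage points higher (within the scatter) from compound 3 to compound 4, 2.5 percentage points apart, within the scatter of two such steps. Both steps lie within the scatter, so the agreement is between two small steps and shows no measurable effect of chloro on either core. The chloro also stands in a different place in each pair, so these steps cannot separate the role of its place from that of the core.

Still open, going by these compounds, is whether a different aromatic substituent, such as methoxy, nitrile or an amine, gives a step beyond the scatter. Also open, on these data alone, is how a longer chain would read in this assay.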